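Swapping the methoxy pattern on a thiazolidine amide

The source may hold more compounds than are shown below. What is called first, only, known or untested is meant among the compounds shown, and "the series" means these compounds.

Three compounds share one core, an octadecyl amide joined to a five-membered ring that carries an aromatic group on a saturated ring carbon. Compound 1 `CCCCCCCCCCCCCCCCCCNC(=O)[C@@H]1CSC(c2cccc(O)c2)N1` gives 5700 nM in a functional assay on DU-145 cells (Homo sapiens) for antiproliferative activity, read by sulforhodamine B assay; a higher number here means a weaker inhibitor, a lower number a stronger inhibitor. Compound 2 `CCCCCCCCCCCCCCCCCCNC(=O)[C@@H]1CSC(c2cc(OC)c(OC)c(OC)c2)N1` gives 3900 nM in this assay, and compound 3 `CCCCCCCCCCCCCCCCCCNC(=O)[C@@H]1CSC(c2ccc(N(C)C)cc2)N1` gives 5300 nM. Compound 2 holds the lowest of the three numbers, yet both neighbours sit within the scatter of it: a 1.5-fold lower number from compound 1 to compound 2 (0.16 log units; within the scatter) and a 1.4-fold higher number from compound 2 to compound 3 (0.13 log units; within the scatter) describe the same picture, so no ranking follows.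

Compound 4 `CCCCCCCCCCCCCCCCCCNC(=O)[C@@H]1CSC(c2c(OC)cc(OC)cc2OC)N1` is not yet measured. It differs from compound 2 by 2,4,6-trimethoxyphenyl in place of 3,4,5-trimethoxyphenyl on a saturated ring carbon. For the measured compounds named here, no measured step swaps one trimethoxyphenyl for another, so the only guide is that changing the aromatic group between compound 1, compound 2 and compound 3 moved this assay only within the scatter. On that basis a step of a 1.2-fold higher number from compound 2 to compound 4 (0.06 log units; within the scatter) is expected, which means essentially none beyond the scatter. Compound 4 is therefore estimated at 4500 nM, with a plausible range from 2000 nM to 10000 nM.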

Compound 4, half-maximal inhibitory concentration: 7300 nM
Estimate against measurement, compound 4: 1.6-fold (0.21 log units) below, and the stated range covers the measured number.
By their numbers in this assay, from the lowest: compounds 2, 3, 1 and 4 (each within the scatter of the next).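

Moving the three methoxy groups around the phenyl ring keeps the same atoms and changes only how they are joined, and in this assay this gives a 1.9-fold higher number from compound 2 to compound 4 (0.27 log units; within the scatter). That is the largest step among these compounds, yet it stays within the scatter, as do a 1.4-fold higher number from compound 3 to compound 4 (0.14 log units; within the scatter) and a 1.3-fold higher number from compound 1 to compound 4 (0.11 log units; within the scatter), so the four aromatic groups on this saturated ring carbon still cannot be ranked. Nothing available offers a reason for any of these numbers.

From the compounds shown here alone, whether any aromatic group here can move the number beyond the scatter remains open, for example a phenyl ring carrying a carboxylic acid or a primary amine. Going by these compounds, all four compounds also share the octadecyl chain, so the effect of a shorter chain is equally open.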